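The compounds below may be only part of what the source reports. "The series", "measured", "known", "first", "only" and "open" are said of these compounds alone.

Compound 3 `N=C(NCCCc1c[nH]cn1)NCCC(c1cccc(F)c1)c1ccccn1` gives 7.88 in a functional assay on cardiac atrium for agonist activity at histamine H2 receptor (Cavia porcellus) (on this read-out lower numbers stand for lower potency and higher numbers for higher potency (the scale is a negative logarithm)), the highest of the three numbers gathered so far. Compound 2 `N=C(NCCCc1c[nH]cn1)NCCC(c1ccc(C(F)(F)F)cc1)c1ccccn1` gives 7.76 in this assay, within the scatter of compound 3, while compound 1 `N=C(NCCCc1c[nH]cn1)NCCCC(c1ccccc1)c1ccccn1` gives 6.61 in this assay, clearly lower. Compound 4 `N=C(NCCCc1c[nH]cn1)NCCC(c1ccccn1)c1ccccn1` has not been measured yet; it differs from compound 3 by pyridin-2-yl in place of 3-fluorophenyl on a saturated chain carbon bound to an aromatic carbon and a saturated chain carbon. For the measured compounds named here, the one measured step of a comparable kind, an exchange of one aromatic ring for another on the same chain carbon, is a number 0.12 log units higher from compound 2 to compound 3 (within the scatter), a change within the scatter. Going by the values given here, that step is the only guide, and it concerns different rings, so only a modest shift is expected here, judged as a number 0.38 log units lower from compound 3 to compound 4 (beyond the scatter). Compound 4 is therefore estimated at 7.5 in this assay, with a range from 6.8 to 8.2.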

Compound 4, negative logarithm of the half-maximal effective concentration: 6.9
Compound 4: middle estimate off by 0.60 log units, on the high side; the measured number falls inside the stated range.
By their numbers in this assay, from the lowest: compounds 1 and 4 (each within the scatter of the next); then compounds 2 and 3 (each within the scatter of the next).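

Swapping one aromatic ring for another on this chain carbon is not always neutral in this assay. The earlier exchange stayed within the scatter, but pyridin-2-yl gives a number 0.98 log units lower from compound 3 to compound 4 (beyond the scatter) and a number 0.86 log units lower from compound 2 to compound 4 (beyond the scatter), so this ring lowers potency relative to both substituted phenyl rings. Nothing measured here explains the drop.

As far as these compounds go, it remains open whether a plain phenyl ring or a pyridin-3-yl ring at this place would match compound 3 or compound 4. The effect of an amine on the phenyl ring is also unknown.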